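This account rests on a few compounds, and the source may have more. Where it says the series, first, only, none or still open, it means among the compounds named here.

Working notes on the series. In a functional assay on SK-OV-3 cells (Homo sapiens) for cytotoxicity, read by MTT assay, with a stated time of 48 h (a lower number here means a stronger inhibitor, a higher number a weaker inhibitor), compound 1 `COc1ccc2[nH]c(=O)c(-c3nc4cc(Cl)ccc4[nH]3)cc2c1` gives only a limit, > 100000 nM. Compound 2 `Cc1ccc2[nH]c(=O)c(-c3nc4cc(Br)ccc4[nH]3)cc2c1` likewise gives only a limit in this assay, > 100000 nM. Compound 2 therefore stands at the limit of > 100000 nM in this assay, at which 2 of the 2 values shown sit, with no numbered value to rank it against. No step between measured compounds is shown. Compound 3 `COc1ccc2[nH]c(=O)c(-c3nc4cc(Br)ccc4[nH]3)cc2c1` differs from compound 2 by methoxy in place of methyl on an aromatic carbon. The step from compound 2 to compound 3 in this assay is expected to be a step that the limit leaves unreadable from compound 2 to compound 3, none beyond the scatter, so compound 3 is estimated at 150000 nM, within 40000 nM to 600000 nM, most likely again reported only as a limit.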

Compound 3, half-maximal inhibitory concentration: > 100000 nM
Compound 3 ended at the assay's limit; the forecaster's own chance of this, stated with the estimate: 85%; the middle value does not contradict the limit.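

No step between compound 1, compound 2 and compound 3 can be read, because all three values are limits: the limit of > 100000 nM in this assay, at which 3 of the 3 values shown sit.

The compounds shown leave open whether methoxy in place of methyl, or bromo in place of chloro, changes cytotoxicity at all.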